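Enaminone series: chloro for methoxy on the aniline ring

The source may report more compounds than this note shows. Statements on the series, on what has been measured and on what is new or still open speak of the compounds shown alone.

Three enaminones have been measured in a functional assay on K562 cells (Homo sapiens) for cytotoxicity, read by trypan blue exclusion, with a stated time of 96 h; on this read-out lower numbers stand for stronger inhibition and higher numbers for weaker inhibition. Compound 1 `COc1ccc(N/C=C\C(=O)c2c(OC)cc(OC)cc2OC)cc1` gives 75000 nM, compound 2 `COc1cc(OC)c(C(=O)/C=C\Nc2ccc(Cl)cc2)c(OC)c1` gives 25000 nM, and compound 3 `COc1ccc(N/C=C\C(=O)c2cc(OC)c(OC)c(OC)c2)cc1` gives 500 nM. The change from compound 1 to compound 2 is chloro in place of methoxy on an aromatic carbon, and it gave a 3.0-fold lower number from compound 1 to compound 2 (0.48 log units; beyond the scatter). Compound 3 stands apart from both: its core differs from that of compound 1, and the difference between the two cores is not broken down here; its value is the lowest of the three.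

Compound 4 `COc1cc(C(=O)/C=C\Nc2ccc(Cl)cc2)cc(OC)c1OC` has not been measured. It differs from compound 3 by chloro in place of methoxy on an aromatic carbon, the same change, at the same place, as that from compound 1 to compound 2. For the measured compounds named here, because the only earlier reading of this change is a 3.0-fold lower number from compound 1 to compound 2 (0.48 log units; beyond the scatter), a step of similar size and direction is expected in this assay, so a 2.9-fold lower number from compound 3 to compound 4 (0.47 log units; beyond the scatter) is estimated, resting on the single measured pair. For compound 4 the expected value in this assay is therefore 170 nM, with a plausible range from 50 nM to 600 nM.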

Compound 4, half-maximal inhibitory concentration: 250 nM
Compound 4: middle estimate off by 1.5-fold (0.17 log units), on the low side; the range from low to high includes it.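

Carried onto the core of compound 3, the change from 4-methoxyphenyl to 4-chlorophenyl gives a 2.0-fold lower number from compound 3 to compound 4 (0.30 log units; within the scatter) in this assay. Set beside the earlier reading, the two steps do not separate, and on this evidence the change carries from one core to the other with no detectable difference in size: the same change on two cores in this assay, a 3.0-fold lower number (0.48 log units; beyond the scatter) from compound 1 to compound 2 and a 2.0-fold lower number (0.30 log units; within the scatter) from compound 3 to compound 4, 1.5-fold (0.18 log units) apart, within the scatter of two such steps

For the compounds shown here, this rests on only two pairs, and the step on the core of compound 3 taken alone lies within the scatter, so it does not establish a real gain on that core or predict the step on any further core. The data do not show what lies behind the step on either core.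

The compounds shown leave open whether a fluoro, bromo, trifluoromethyl, nitrile or amine group at this place on the ring would read like chloro or like methoxy. From the compounds shown here alone, whether the step holds on any read-out other than this assay also remains open.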